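Three inactive compounds and an ethoxy replacement

This account rests on a few compounds, and the source may have more. Where it says the series, first, only, none or still open, it means among the compounds named here.

Compound 1, `COc1cc(-n2ncnc2-c2cccc([N+](=O)[O-])c2)cc(OC)c1OC`, gives > 10000 nM in a functional assay on MCF7 cells (Homo sapiens) for antiproliferative activity, read by MTT assay, with a stated time of 72 h; a higher number here means a weaker inhibitor, a lower number a stronger inhibitor.
Compound 2, `COc1cc(-c2ncnn2-c2ccc(Cl)c(Cl)c2)cc(OC)c1OC`, gives > 10000 nM in this assay.
Compound 3, `COc1cc(-c2ncnn2-c2ccc([N+](=O)[O-])cc2)cc(OC)c1OC`, gives > 10000 nM in this assay.

Each of these three values is a limit of the assay and not a number: the compound showed no measurable effect up to the highest concentration tested. Compound 1 therefore stands at that limit, and it stands there together with the other two, as summarised in the limit of > 10000 nM in this assay, at which 3 of the 3 values shown sit. No step between two measured compounds is shown here, so there is nothing to say about how a single change moves this read-out.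

Compound 4, `CCOc1cccc(-c2ncnn2-c2cc(OC)c(OC)c(OC)c2)c1`, differs from compound 1 by ethoxy in place of nitro on an aromatic carbon. Since compound 1 sits at the limit and nothing measured here shows a change in either direction, no step beyond the usual scatter is expected from compound 1 to compound 4, and the estimated step is a step that the limit leaves unreadable from compound 1 to compound 4. The expected value for compound 4 in this assay is 15000 nM, in the range from 3000 nM to 60000 nM.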

Compound 4, half-maximal inhibitory concentration: > 10000 nM
Compound 4 gave a limit, no number; the forecaster's own chance of this, stated with the estimate: 70%; the middle value does not contradict the limit.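

Compound 4 gives > 10000 nM in this assay, which is a limit and not a number. Compound 1 also stands at a limit, so no step between compound 1 and compound 4 can be read: the limit of > 10000 nM in this assay, at which 4 of the 4 values shown sit.

The compounds shown leave open which structural change, if any, would give a measurable value.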